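This account rests on a few compounds, and the source may have more. Where it says the series, first, only, none or still open, it means among the compounds named here.

Compound 1 `CC(=O)Nc1ccc(S(=O)(=O)Oc2ccccc2C(C)C)cc1`: 12000 nM
Compound 2 `CC(=O)Nc1ccc(S(=O)(=O)Oc2ccccc2I)cc1`: 17000 nM
Compound 3 `CC(C)c1ccccc1OS(=O)(=O)c1ccc(NC(=O)CCCCl)cc1`: 3800 nM

All three were tested in a functional assay on HT-1080 cells (Homo sapiens) for antiproliferative activity, read by sulforhodamine B assay, with a stated time of 48 h; on this read-out higher numbers stand for weaker inhibition and lower numbers for stronger inhibition. Compound 3 gives the lowest of the three numbers; the step of a 3.2-fold lower number from compound 1 to compound 3 (0.50 log units; beyond the scatter) corresponds to the difference (2-chloroethyl in place of hydrogen on a saturated chain carbon bound to a carbonyl carbon), which is how the core of compound 3 differs from the core of compound 1. Compound 1 and compound 2 differ by iodo in place of isopropyl on an aromatic carbon, and this change gave the step of a 1.4-fold higher number from compound 1 to compound 2 (0.15 log units; within the scatter).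

Compound 4 `O=C(CCCCl)Nc1ccc(S(=O)(=O)Oc2ccccc2I)cc1` has not yet been measured in this assay. Relative to compound 3 it carries the same change, (iodo in place of isopropyl on an aromatic carbon), at the same place. Because the step of a 1.4-fold higher number from compound 1 to compound 2 (0.15 log units; within the scatter) lies within the scatter, the expectation for compound 4 is a comparable step, a 1.3-fold higher number from compound 3 to compound 4 (0.12 log units; within the scatter). Compound 4 is therefore estimated to give about 5000 nM, expected to fall between 2500 nM and 10000 nM.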

Compound 4, half-maximal inhibitory concentration: 12000 nM
For compound 4 the middle estimate is 2.4-fold (0.38 log units) below the measured one; measured number above the stated range.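

In this assay, iodo in place of isopropyl on an aromatic carbon gave a 3.2-fold higher number from compound 3 to compound 4 (0.50 log units; beyond the scatter), and this step cannot be told apart from the one on the other core: the same change on two cores in this assay, a 1.4-fold higher number (0.15 log units; within the scatter) from compound 1 to compound 2 and a 3.2-fold higher number (0.50 log units; beyond the scatter) from compound 3 to compound 4, 2.2-fold (0.35 log units) apart, within the scatter of two such steps. With 2-chloroethyl in place of hydrogen on a saturated chain carbon bound to a carbonyl carbon, the step was a 1.4-fold lower number from compound 2 to compound 4 (0.15 log units; within the scatter), and the comparison reads the same way: the same change on two cores in this assay, a 3.2-fold lower number (0.50 log units; beyond the scatter) from compound 1 to compound 3 and a 1.4-fold lower number (0.15 log units; within the scatter) from compound 2 to compound 4, 2.2-fold (0.35 log units) apart, within the scatter of two such steps. Each change thus carried over from one core to the other within the scatter, but two cores cannot show that a step keeps its size on further cores.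

The compounds shown leave open how a bromo or a methoxy group on that aromatic carbon would read in this assay. They also leave open how an amine or a longer chain in place of 2-chloroethyl would read there.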